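Dimethylamino for imidazolyl on a butynyl chain

A few compounds are considered here, and "the series" means these few. Any claim that something is new, unique, unknown or untested is made for them only; others in the source may bear on it.

Compound 1 `CC1CCC(=O)N1CC#CCn1ccnc1` and compound 2 `CC1CCC(=O)N1CC#CCN(C)C` share one core; compound 3 `Cn1ccn(CC#CCn2ccnc2)c1=O` and the as yet unmeasured compound 4 `CN(C)CC#CCn1ccn(C)c1=O` share another. The difference between the two cores is not broken down here. In a functional assay on the whole organism for agonist activity, with Mus musculus as the target (on this read-out lower numbers stand for an effect already at smaller amounts and higher numbers for an effect only at larger amounts of compound), compound 1 gives only a limit, > 100 mg/kg. Compound 2 gives 3.7 mg/kg in this assay, so the step of an at least 27-fold lower number from compound 1 to compound 2 (1.43 log units; beyond the scatter) is open-ended and rests on (the limit of > 100 mg/kg in this assay, at which 1 of the 3 values shown sits). The change behind that step is dimethylamino in place of 1H-imidazol-1-yl on a saturated chain carbon bound to a triple-bonded carbon. Compound 3 gives 4.4 mg/kg in this assay, a value within the scatter of that of compound 2. Compound 4 carries the same change on the other core: dimethylamino in place of 1H-imidazol-1-yl on a saturated chain carbon bound to a triple-bonded carbon. Both place descriptions read the same word for word, so the change is the same, only on a different core. Going by these compounds, the measured step starts from a limit and its full size is unknown, so the expectation is held to a moderate step. For compound 4 a step of a 2.9-fold lower number from compound 3 to compound 4 (0.47 log units; beyond the scatter) is expected in this assay. Compound 4 is therefore estimated at 1.5 mg/kg in this assay, with a range from 0.3 mg/kg to 8 mg/kg.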

Compound 4, dose for half-maximal effect: 8 mg/kg
The estimate for compound 4 lay 5.3-fold (0.73 log units) below the measured number; measured number inside the range.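

In this assay, putting dimethylamino in place of 1H-imidazol-1-yl on the core of compound 3 gives a 1.8-fold higher number from compound 3 to compound 4 (0.26 log units; within the scatter), so on this core the two groups cannot be told apart. The change therefore does not carry its size from one core to the other: the same change on two cores in this assay, an at least 27-fold lower number (1.43 log units; beyond the scatter) from compound 1 to compound 2 and a 1.8-fold higher number (0.26 log units; within the scatter) from compound 3 to compound 4, at least 49-fold (1.69 log units) apart, beyond the scatter of two such steps. The earlier step rests on a limit for compound 1, > 100 mg/kg, so its full size stays unknown, and two pairs show only that the result of this change differs between these cores, not which part of the cores accounts for it.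

The compounds shown leave open whether another amine, such as diethylamino or pyrrolidin-1-yl, on a saturated chain carbon bound to a triple-bonded carbon would follow the pair on the core of compound 1 or the pair on the core of compound 3. Also open, going by these compounds, is whether a longer chain between the two ends would keep the same difference between the cores.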